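This account rests on a few compounds, and the source may have more. Where it says the series, first, only, none or still open, it means among the compounds named here.

Two members of the series are in hand. Compound 1 `CC(O)n1cnc2c(Cl)nc(I)nc21` carries chloro on the aromatic carbon where compound 2 `CC(O)n1cnc2c(N)nc(I)nc21` carries amino. In a functional assay on MOLT-4 cells (Homo sapiens) for inhibition (a lower number here means a stronger inhibitor, a higher number a weaker inhibitor), compound 1 returns only a limit, > 500000 nM. In this assay compound 2 likewise returns only a limit, > 500000 nM. The step that the two limits leave unreadable from compound 1 to compound 2 therefore cannot be read, as both ends sit at the limit of > 500000 nM in this assay, at which 2 of the 2 values shown sit. Compound 2 thus stands at a limit in this assay with no number of its own, and compound 1 gives no foothold either.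

The next compound, compound 3 `Nc1nc(I)nc2c1ncn2OCCO`, differs from compound 2 by 2-hydroxyethoxy in place of 1-hydroxyethyl on an aromatic nitrogen. For the measured compounds named here, no measured step touches this position; the only step in hand, from chloro to amino, is unreadable. With both measured values at a limit, no direction can be drawn, and the step expected in this assay is a number no higher from compound 2 to compound 3 (the limit leaves the size open), which most probably means another limit. Compound 3 is accordingly estimated at 500000 nM in this assay, with a range from 100000 nM to 2000000 nM.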

Compound 3, half-maximal inhibitory concentration: > 500000 nM
Compound 3 was reported as a limit; the forecaster's own chance of this, stated with the estimate: 80%; the middle value sits exactly at the limit.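

Compound 3 returns only a limit in this assay, as compound 2 does, so no new step can be read between compound 2 and compound 3: the limit of > 500000 nM in this assay, at which 3 of the 3 values shown sit.

The compounds shown leave open whether any change to the shared core, on the aromatic carbon or the aromatic nitrogen, gives a measurable inhibition in this assay, and how large such a step would be.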